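The compounds below may be only part of what the source reports. "The series", "measured", "known", "first", "only" and "open" are said of these compounds alone.

Compound 1 `Cc1ccc(N)cc1S(=O)(=O)N(C)/N=C/c1cnn2ccc(C#N)cc12` gives > 1000 nM.
Compound 2 `Cc1ccc([N+](=O)[O-])cc1S(=O)(=O)N(Cc1ccccc1)/N=C/c1cnn2ccc(C#N)cc12` gives > 1000 nM.
Compound 3 `CCc1ccc([N+](=O)[O-])cc1S(=O)(=O)N(C)/N=C/c1cnn2ccc(C#N)cc12` gives 280 nM.

All three were tested in an assay on isolated protein for inhibition of phosphatidylinositol 4,5-bisphosphate 3-kinase catalytic subunit beta isoform (Homo sapiens), read by 33P incorporation, with a stated time of 60 min; on this read-out higher numbers stand for weaker inhibition and lower numbers for stronger inhibition. The value for compound 1 is a limit of the assay, not a number. The value for compound 2 is also a limit. Among the compounds with values here, compound 3 is the only one with an actual number, 280 nM. So compound 1 stands at the limit of > 1000 nM in this assay, at which 2 of the 3 values shown sit, and how far it lies from compound 3 cannot be read from this.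

Compound 4 `Cc1ccccc1S(=O)(=O)N(C)/N=C/c1cnn2ccc(C#N)cc12` differs from compound 1 by hydrogen in place of amino on an aromatic carbon. Within the data shown here, no measured pair differs in only this place, so no measured step guides the expectation. A step that the limit leaves unreadable from compound 1 to compound 4 that stays near the limit is expected. Compound 4 is expected to give 1500 nM, between 300 nM and 8000 nM.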

Compound 4, half-maximal inhibitory concentration: > 1000 nM
Compound 4: no number, only a limit; the forecaster's own chance of this, stated with the estimate: 55%; the middle value is on the limit's open side.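

Within the data shown here, compound 1 and compound 4 both give only a limit of the assay, not a number, so no step between them can be read. Going by these compounds, whether hydrogen in place of amino changes inhibition at all remains open.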